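The source may report more compounds than this note shows. Statements on the series, on what has been measured and on what is new or still open speak of the compounds shown alone.

Measured so far in a functional assay for antagonist activity at transient receptor potential cation channel subfamily V member 1 (Homo sapiens), read by FLIPR; a lower number here means a stronger inhibitor, a higher number a weaker inhibitor:
- compound 1 `C[C@@H]1CN(c2ncccc2C(F)(F)F)CCN1C(=O)Nc1ccc(C(F)(F)F)cc1` gives 17 nM
- compound 2 `N#Cc1ccc(NC(=O)c2ccc(-c3ncccc3C(F)(F)F)cc2)cc1` gives 417 nM
- compound 3 `Cc1cccnc1-c1ccc(C(=O)Nc2ccc(F)cc2)cc1` gives > 4000 nM, which is a limit of the assay and not a number

Among the compounds with values here, compound 3 thus stands at the limit of > 4000 nM in this assay, at which 1 of the 3 values shown sits; where it lies beyond that limit is unknown, and no step to compound 1 or compound 2 can be sized from it. Compound 1 and compound 2 differ from compound 3 in more than one place, so their values show only that the series reaches into the low range.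

Compound 4 `Cc1cccnc1-c1ccc(C(=O)Nc2ccc(C(F)(F)F)cc2)cc1` keeps the core of compound 3 and makes one change: trifluoromethyl in place of fluoro on an aromatic carbon. Within the data shown here, no measured pair isolates this change. Compound 1 carries a trifluoromethyl on the corresponding ring and gives 17 nM, but on a different core, so it is no direct guide. Compound 4 is expected to move below the limit by a step of an at least 2.0-fold lower number from compound 3 to compound 4 (0.30 log units; that floor lies within the scatter) in this assay, with considerable uncertainty. The estimate for compound 4 in this assay is 2000 nM, within 400 nM to 8000 nM, and a limit-only result remains possible.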

Compound 4, half-maximal inhibitory concentration: 65 nM
For compound 4 the middle estimate is 31-fold (1.49 log units) above the measured one; measured number below the stated range.
By their numbers in this assay, from the lowest: compound 1; then compound 4; then compound 2. At a limit, above all of these: compound 3.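

On the shared core, trifluoromethyl in place of fluoro on an aromatic carbon, para to a large group, gives an at least 61-fold lower number from compound 3 to compound 4 (1.78 log units; beyond the scatter) in this assay. Within the data shown here, this is the first step that isolates one place, and it shows that this single change is enough to bring the core from an assay limit into the measured range. The step is only a floor, since the value of compound 3 is a limit and not a number: the limit of > 4000 nM in this assay, at which 1 of the 4 values shown sits.

The compounds shown do not tell whether this gain is specific to trifluoromethyl or would also appear with a chlorine atom, a methoxy, a tert-butyl or an amine at this position. From the compounds shown here alone, whether the same change carries the same weight on the core of compound 1 also remains open.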